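Sulfonanilide series: acid dissociation notes

The compounds below may be only part of what the source reports. "The series", "measured", "known", "first", "only" and "open" are said of these compounds alone.

Measured compounds:
compound 1, `Cc1ccc(S(=O)(=O)Nc2cccc([N+](=O)[O-])c2)cc1`, 8.27
compound 2, `O=[N+]([O-])c1cccc(NS(=O)(=O)c2ccc(F)cc2)c1`, 7.85
compound 3, `COc1ccc(S(=O)(=O)Nc2ccc(F)cc2)cc1`, 9.32

In an ADME assay, compound 3 gives the highest of the three numbers; compound 1 lies closer to it, compound 2 furthest away. Compound 4, `COc1ccc(S(=O)(=O)Nc2ccc(C)cc2)cc1`, is not yet measured. Compound 4 differs from compound 3 by methyl in place of fluoro on an aromatic carbon. The same change is seen between the measured pair, where compound 1 differs from compound 2 by methyl in place of fluoro on an aromatic carbon; that step is a number 0.42 log units higher from compound 2 to compound 1 (beyond the scatter). The difference between the cores of compound 3 and compound 2 is not broken down here, so only the two values speak for it. For the measured compounds named here, because the only precedent is a number 0.42 log units higher from compound 2 to compound 1 (beyond the scatter), a step of about that size is expected for compound 4, a number 0.42 log units higher from compound 3 to compound 4 (beyond the scatter). For compound 4 in this assay the estimate is 9.74, with a range from 9.35 to 10.15.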

Compound 4, acid dissociation constant: 9.8
Compound 4: the middle estimate sits 0.06 log units below what was measured; low and high end bracket the measured number.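

In this assay, methyl in place of fluoro on an aromatic carbon of the core of compound 3 gives a step of a number 0.48 log units higher from compound 3 to compound 4 (beyond the scatter). The change carries from one core to the other without a difference that can be told apart: the same change on two cores in this assay, a number 0.42 log units higher (beyond the scatter) from compound 2 to compound 1 and a number 0.48 log units higher (beyond the scatter) from compound 3 to compound 4, 0.06 log units apart, within the scatter of two such steps This rests on two pairs only; it does not establish the step on other cores, and it does not explain why the step arises.

Methyl and fluoro are the only two groups compared at this place. On these data alone, whether a nitrile, an amine, a carboxylic acid or a longer chain there would follow the same scale remains open.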